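The source may hold more compounds than are shown below. What is called first, only, known or untested is meant among the compounds shown, and "the series" means these compounds.

Compound 1, `COc1ccc(Nc2nc(-c3cccc(F)c3)nc3ccc(F)cc23)cc1`: 42300 nM
Compound 2, `Fc1cccc(-c2nc(Nc3cccc(Br)c3)c3cc(F)ccc3n2)c1`: > 50000 nM

In a functional assay on HT29-AK cells (Homo sapiens) for cytotoxicity, read by MTT assay, with a stated time of 48 h (a lower number here means a stronger inhibitor, a higher number a weaker inhibitor), compound 1 gives 42300 nM. For compound 2 the number is only a limit of the assay, > 50000 nM, as recorded in the limit of > 50000 nM in this assay, at which 1 of the 2 values shown sits. Because of that limit, the step of an at least 1.1-fold higher number from compound 1 to compound 2 (0.07 log units; that floor lies within the scatter) is known only by its floor, and that floor lies within the scatter. Compound 2 therefore stands at the weak end of the two measured compounds, without a firm number of its own.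

Compound 3, `Nc1ccccc1Nc1nc(-c2cccc(F)c2)nc2ccc(F)cc12`, differs from compound 2 in one place: 2-aminophenyl in place of 3-bromophenyl on a nitrogen on an aromatic ring. Among the compounds with values here, the one measured step, an at least 1.1-fold higher number from compound 1 to compound 2 (0.07 log units; that floor lies within the scatter), also exchanged the group on the same nitrogen and did no more than push the number to the limit. Within the data shown here, no measured step involves a 2-aminophenyl group, so there is nothing to suggest that this change would pull the number down. The expected step is thus an at least 1.1-fold lower number from compound 2 to compound 3 (0.04 log units; that floor lies within the scatter) in this assay, nothing beyond the scatter. Compound 3 is estimated to give 45000 nM, with a range from 15000 nM to 150000 nM, and a real chance that only a limit is reported again.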

Compound 3, half-maximal inhibitory concentration: > 50000 nM
Compound 3: no number, only a limit; the forecaster's own chance of this, stated with the estimate: 55%; middle value at least 1.1-fold (0.04 log units) away from the limit.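

Placing 2-aminophenyl on the nitrogen brings in a hydrogen-bond donor and a hydrogen-bond acceptor that 3-bromophenyl lacks, yet in this assay this exchange still yields no firm number, so a second, quite different group at this position now ends at the limit of the assay. Set against the 4-methoxyphenyl group, the same 2-aminophenyl group gives an at least 1.1-fold higher number from compound 1 to compound 3 (0.07 log units; that floor lies within the scatter), which means this comparison is known only by its floor and gives no firm sign that either group on the nitrogen does better than the other. The step from compound 2 to compound 3 cannot be read because both compounds sit at the same limit: the limit of > 50000 nM in this assay, at which 2 of the 3 values shown sit.

Going by these compounds, how far compound 2 and compound 3 truly lie past that limit stays open, and with it any order among the three groups on this nitrogen. Also open, on these data alone, is whether a pyridine ring or a longer alkyl chain in place of these substituted phenyl groups would give a firm number in this assay.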